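The source may hold more compounds than are shown below. What is called first, only, known or untested is meant among the compounds shown, and "the series" means these compounds.

The story here is a single change on a shared core, read in a physicochemical assay for solubility, at pH 7; on this read-out lower numbers stand for lower solubility and higher numbers for higher solubility. Compound 3 `CN1CCC(C(=O)N2Cc3c(NC(=O)c4ccco4)n[nH]c3C2(C)C)CC1` has already been measured, and its result is a limit of the assay rather than a number: in this assay compound 3 gives > 225000 nM. Compound 3 therefore stands at the top of what the measurement can report. That is not unusual in this set, because of the limit of > 225000 nM in this assay, at which 2 of the 3 values shown sit. Compound 2 `CC1(C)c2[nH]nc(NC(=O)c3ccc(F)cc3)c2CN1C(=O)C1CCN(C2CC2)CC1` also comes back as a limit, giving > 225000 nM in this assay. Compound 1 `CC(C)(C)C(=O)N1Cc2c(NC(=O)c3ccncc3)n[nH]c2C1(C)C` returns a true number, 205000 nM in this assay, so all three measured compounds sit close together at the high end of the scale. Going by the values given here, no two of them differ in only one place, so no measured step is available to guide the next move.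

Compound 4 `CN1CCC(C(=O)N2Cc3c(NC(=O)c4ccc(Cl)cc4)n[nH]c3C2(C)C)CC1` is the compound still to be measured. It differs from compound 3 by 4-chlorophenyl in place of furan-2-yl on a carbonyl carbon. Without a measured step to rest on, the expectation is that the solubility comes down off the limit into the range the assay can report, a step expected to be an at least 2.2-fold lower number from compound 3 to compound 4 (0.35 log units; beyond the scatter). For compound 4 the estimate in this assay is 100000 nM, with a likely range from 30000 nM to 225000 nM.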

Compound 4, solubility: > 225000 nM
Compound 4 gave a limit, no number; the forecaster's own chance of this, stated with the estimate: 30%; middle value at least 2.2-fold (0.35 log units) from the limit.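

In this assay compound 4 gives > 225000 nM, which is a limit and not a number. Compound 3 also carries a limit, so the step between compound 3 and compound 4 cannot be read. The compounds shown leave open whether 4-chlorophenyl in place of furan-2-yl changes the read-out at all.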